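Chloro to bromo: from compound 2 to compound 4

This account rests on a few compounds, and the source may have more. Where it says the series, first, only, none or still open, it means among the compounds named here.

- compound 1 `COc1cc(NCc2scnc2C)ccc1-c1cnco1` gives 73700 nM
- compound 2 `COc1cc(NCc2ccc(Cl)s2)ccc1-c1cnco1` gives 53800 nM
- compound 3 `COc1cc(/N=C/c2ccc(F)cc2)ccc1-c1cnco1` gives 325000 nM

In an ADME assay on Vero cells (Chlorocebus sabaeus) for cytotoxicity, read by MTT assay, with a stated time of 96 h (on this read-out higher numbers stand for lower toxicity in this test and lower numbers for higher toxicity in this test), compound 2 and compound 1 lie within the scatter of each other at the low end of the three numbers, while compound 3 gives a clearly higher number, 325000 nM.

Compound 4 `COc1cc(NCc2ccc(Br)s2)ccc1-c1cnco1` has not yet been measured. It departs from compound 2 in one place: bromo in place of chloro on an aromatic carbon. In short, this is bromo in place of chloro on an aromatic carbon.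

Among the compounds with values here, no measured pair makes this exact exchange, so the data hold no direct precedent. Within the data shown here, the only measured step is a 1.4-fold lower number from compound 1 to compound 2 (0.14 log units; within the scatter), and it stays within the scatter. Among the measured compounds shown here, compound 3 is not linked to compound 2 by any single change, so it offers no step to compare. For the measured compounds named here, with a 1.4-fold lower number from compound 1 to compound 2 (0.14 log units; within the scatter) as the sole guide, the exchange of one halogen for another is not expected to produce a step beyond the scatter in this assay, and no direction is favoured. The expected change is a 1.1-fold lower number from compound 2 to compound 4 (0.03 log units; within the scatter).

Compound 4 is estimated at 50000 nM, with an expected range from 26000 nM to 95000 nM.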

Compound 4, half-maximal cytotoxic concentration: 47300 nM
Estimate against measurement, compound 4: 1.1-fold (0.02 log units) above; low and high end bracket the measured number.
By their numbers in this assay, from the lowest: compounds 4, 2 and 1 (each within the scatter of the next); then compound 3.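

In this assay, within the data shown here, the step of a 1.1-fold lower number from compound 2 to compound 4 (0.06 log units; within the scatter) gives the first direct reading of a halogen exchange on this aromatic carbon of the five-membered aromatic ring with 1 sulfur, next to the ring sulfur, and this exchange of chloro for bromo stays within the scatter. The step of a 1.6-fold lower number from compound 1 to compound 4 (0.19 log units; within the scatter) adds a second comparison with the 4-methyl-1,3-thiazol-5-yl group, and together with the step of a 1.4-fold lower number from compound 1 to compound 2 (0.14 log units; within the scatter) it places both 5-halothiophen-2-yl groups within the scatter of that group in this test. Nothing measured on these compounds explains this absence of a clear step, and no supporting data on the chloro or bromo groups are available.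

Still open, going by these compounds, is whether a group other than chloro or bromo on this carbon, such as a nitrile, a methoxy group or a carboxylic acid, would also stay within the scatter, and whether a thiophen-2-yl group carrying only hydrogen there would do the same. The clearly higher number of compound 3 also remains unassigned, as no single change links it to compound 1, compound 2 or compound 4.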